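Trifluoromethyl Added Beside Chloro in an Inactive Series

A few compounds are considered here, and "the series" means these few. Any claim that something is new, unique, unknown or untested is made for them only; others in the source may bear on it.

Three compounds share one core and differ only in the substituted aryl ring of the sulfonyl group. Compound 1 `O=S(=O)(Nc1ccc2oc(-c3ccccc3)nc2c1)c1cccc(C(F)(F)F)c1` carries a trifluoromethyl on that ring. In an assay on isolated protein for inhibition of malate dehydrogenase, mitochondrial (Sus scrofa), with stated times of 45 min and 30 min (on this read-out lower numbers stand for stronger inhibition and higher numbers for weaker inhibition), compound 1 gives only the assay limit > 63000 nM and no number. Compound 2 `O=S(=O)(Nc1ccc2oc(-c3ccccc3)nc2c1)c1ccc(F)c(C(F)(F)F)c1` adds a fluoro. In this assay compound 2 likewise reaches only the limit > 63000 nM. The step that the two limits leave unreadable from compound 1 to compound 2 is therefore unreadable. Compound 3 `O=S(=O)(Nc1ccc2oc(-c3ccccc3)nc2c1)c1ccc(Cl)cc1` carries a chloro instead. In this assay compound 3 also stands at the limit > 63000 nM, so no number is known for it. All three values sit at the limit of > 63000 nM in this assay, at which 3 of the 3 values shown sit.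

Compound 4 `O=S(=O)(Nc1ccc2oc(-c3ccccc3)nc2c1)c1ccc(Cl)c(C(F)(F)F)c1` differs from compound 3 by trifluoromethyl in place of hydrogen on an aromatic carbon, ortho to a chloro group and meta to a large group. Within the data shown here, the only measured step, from compound 1 to compound 2, has no readable size, and compound 1 and compound 3 already carry the groups that compound 4 combines without either giving a number. The expectation for this assay is that compound 4 remains at the limit, with the step that the limit leaves unreadable from compound 3 to compound 4 expected to show nothing beyond it. Compound 4 is estimated at 100000 nM, between 40000 nM and 300000 nM.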

Compound 4, half-maximal inhibitory concentration: > 63000 nM
Compound 4 gave a limit, no number; the forecaster's own chance of this, stated with the estimate: 85%; the middle value lies beyond the limit too.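

In this assay compound 4 gives only a limit, so its steps from compound 1, compound 2 and compound 3 cannot be read, and no new step emerges: the limit of > 63000 nM in this assay, at which 4 of the 4 values shown sit.

The compounds shown leave open how far each lies beyond that limit, and whether any change on the aryl ring of the sulfonyl group would give a number in this assay.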